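The source may hold more compounds than are shown below. What is called first, only, known or untested is meant among the compounds shown, and "the series" means these compounds.

Measured compounds:
- compound 1 `O=S(=O)(c1ccccc1Cl)n1cc(C2=CCNCC2)c2ccccc21` gives 97% in a functional assay on HeLa cells for inhibition of 5-hydroxytryptamine receptor 6 (Homo sapiens), read by cAMP accumulation; a lower number here means a smaller maximal response, a higher number a larger maximal response
- compound 2 `O=S(=O)(c1ccccc1F)n1cc(C2=CCNCC2)c2ccccc21` gives 100% in this assay

Compound 2 and compound 1 give numbers that cannot be told apart: the step of a number 3 percentage points higher from compound 1 to compound 2 (within the scatter) lies within the scatter, so neither stands out, and both reach roughly the full response of the control.

Compound 3 `O=S(=O)(c1ccc(Cl)s1)n1cc(C2=CCNCC2)c2ccccc21` has not yet been measured. It differs from compound 2 in one place: 5-chlorothiophen-2-yl in place of 2-fluorophenyl on a sulfonyl sulfur. Among the compounds with values here, the one measured step, a number 3 percentage points higher from compound 1 to compound 2 (within the scatter), swaps one halogen for another while the aromatic ring on the sulfonyl sulfur stays the same; it does not cover an exchange of the ring itself, so it bears on the new change only loosely. What it does show is that the maximal response in this assay stayed put through the one variation seen so far.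

On that basis compound 3 is expected to show a step of a number 5 percentage points lower from compound 2 to compound 3 (within the scatter), that is, none beyond the scatter. Within the data shown here, the estimated value for compound 3 in this assay is 95%, with a range from 75% to 105%; the range is wider than the scatter alone because no measured step tests a change of this kind.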

Compound 3, largest response reached (reported as Imax), in percent of the reference or control that the assay uses: 83%
The estimate for compound 3 lay 12 percentage points above the measured number; low and high end bracket the measured number.
By their numbers in this assay, from the lowest: compound 3; then compounds 1 and 2 (each within the scatter of the next).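

Within the data shown here, changing the ring on the sulfonyl sulfur, rather than only the halogen on it, is the first change that moves the maximal response in this assay beyond the scatter: the result is a number 17 percentage points lower from compound 2 to compound 3 (beyond the scatter) and likewise a number 14 percentage points lower from compound 1 to compound 3 (beyond the scatter). This position is therefore not indifferent to its group, although the drop with 5-chlorothiophen-2-yl is modest and a sizeable response remains. Nothing available explains why the response falls.

On these data alone, it remains open whether the five-membered ring or its chlorine accounts for the step, a question that a plain thiophen-2-yl group would help to settle. Also open, as far as these compounds go, is how the response would change with an amine or a carboxylic acid on the ring at this position.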